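Bromo for chloro at the aromatic carbon: compound 4

A few compounds are considered here, and "the series" means these few. Any claim that something is new, unique, unknown or untested is made for them only; others in the source may bear on it.

Of the compounds shown here, three have been measured in a functional assay on SKHep cells (Homo sapiens) for antiproliferative activity, read by MTT assay, with a stated time of 12 h; on this read-out lower numbers stand for stronger inhibition and higher numbers for weaker inhibition. Compound 1 `COc1ccc2oc(/C=C/c3ccc(OC(F)(F)F)cc3)cc(=O)c2c1` gives only a limit in this assay, > 40000 nM. Compound 2 `COc1cc(OC)c2c(=O)cc(/C=C/c3ccccc3)oc2c1` gives 26000 nM in this assay, and compound 3 `COc1cc(OC)c2c(=O)cc(/C=C/c3ccc(Cl)cc3)oc2c1` gives 26900 nM. Compound 3 thus carries the higher of the two numbers shown, with compound 2 nearest to it, and the single step between measured compounds that differ in one place, a 1.0-fold higher number from compound 2 to compound 3 (0.01 log units; within the scatter), is within the scatter. Among the compounds with values here, the only further piece of evidence is the limit of > 40000 nM in this assay, at which 1 of the 3 values shown sits, which concerns compound 1 alone.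

Compound 4 `COc1cc(OC)c2c(=O)cc(/C=C/c3ccc(Br)cc3)oc2c1` is not yet measured. It differs from compound 3 in one place: bromo in place of chloro on an aromatic carbon. The new group sits on an aromatic carbon of a six-membered aromatic ring of carbon only, para to a large group. Within the data shown here, no measured step exchanges one halogen for another. The closest comparison is the step from hydrogen to chloro, a 1.0-fold higher number from compound 2 to compound 3 (0.01 log units; within the scatter), which moved the number within the scatter. On this basis the expected step of a 1.1-fold lower number from compound 3 to compound 4 (0.03 log units; within the scatter) is none beyond the scatter. Compound 4 is therefore estimated at 25000 nM in this assay, expected to lie between 10000 nM and 60000 nM. A reading reported only as a limit cannot be ruled out.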

Compound 4, half-maximal inhibitory concentration: > 40000 nM
Compound 4 was reported as a limit (the forecaster's own chance of this, stated with the estimate: 25%); at least 1.6-fold (0.20 log units) between middle value and limit.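

In this assay, from the compounds shown here alone, bromo on this aromatic carbon, para to a large group, can be read against chloro (an at least 1.4-fold higher number from compound 3 to compound 4 (0.17 log units; that floor lies within the scatter)) and against hydrogen (an at least 1.5-fold higher number from compound 2 to compound 4 (0.18 log units; that floor lies within the scatter)), but compound 4 is reported only as a limit, so each step is a floor and its actual size is unknown. The earlier exchange of hydrogen for chloro gave a step between two numbers (a 1.0-fold higher number from compound 2 to compound 3 (0.01 log units; within the scatter)), whereas the bromo steps are open on the upper side: they may stay within the scatter or go beyond it, and they point only towards a higher number, that is, weaker inhibition. The limit is also no longer confined to compound 1, since it now appears among the compounds sharing the core of compound 4: the limit of > 40000 nM in this assay, at which 2 of the 4 values shown sit.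

Still open, going by these compounds, is the actual value of compound 4, and with it whether 4-chlorophenyl and 4-bromophenyl truly differ at this place. Also open, on these data alone, is whether an amine or a carboxylic acid at this position on the core of compound 2 would move the number beyond the scatter in either direction.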